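The source may hold more compounds than are shown below. What is called first, only, known or untested is meant among the compounds shown, and "the series" means these compounds.

Compound 1 `O=C(Nc1ccc(Oc2ccnc3[nH]ccc23)c(F)c1)c1nn(-c2ccccc2)ccc1=O` and compound 2 `Cn1ccc2c(Oc3ccc(NC(=O)c4nn(-c5ccccc5)ccc4=O)cc3)ccnc21` share an amide-linked scaffold and are both weak in a functional assay on HepG2 cells (Homo sapiens) for cytotoxicity, read by MTT assay, with a stated time of 72 h; on this read-out lower numbers stand for stronger inhibition and higher numbers for weaker inhibition: compound 1 gives 24900 nM, and compound 2 gives 56200 nM. Compound 3 `COc1ccc(-n2ccc(=O)c(C(=O)Nc3ccc(Oc4ccnc5c4ccn5C)c(F)c3)n2)cc1` carries a 4-methoxyphenyl on the pyridazinone nitrogen together with a fluorine on the central ring. In this assay compound 3 reaches only a limit, > 60000 nM, so no number stands for it. Compound 4 `Cn1ccc2c(Oc3ccc(NC(=O)c4nn(-c5ccccc5)ccc4=O)cc3F)ccnc21` is the next member: the change from compound 3 is hydrogen in place of methoxy on an aromatic carbon, para to a large group. Among the measured compounds shown here, no single-change step between measured compounds exists to anchor this move, and all three measured values sit at weak inhibition, so no step beyond the usual scatter is expected in this assay from compound 3 to compound 4; if anything, a slight gain is expected, since compound 4 closely resembles compound 2 with 56200 nM. For compound 4 the expected value in this assay is 40000 nM, between 15000 nM and 100000 nM, a step of an at least 1.5-fold lower number from compound 3 to compound 4 (0.17 log units; that floor lies within the scatter).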

Compound 4, half-maximal inhibitory concentration: > 60000 nM
Compound 4: a limit, no number (the forecaster's own chance of this, stated with the estimate: 35%); middle value at least 1.5-fold (0.17 log units) from the limit.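

Among the compounds shown here, compound 4 gives the first direct reading of the methyl on the aromatic nitrogen with the fluorine held in place: methyl in place of hydrogen gives an at least 2.4-fold higher number from compound 1 to compound 4 (0.38 log units; beyond the scatter), so the hydrogen form, compound 1, is the stronger of this pair in this assay. Fluoro in place of hydrogen on an aromatic carbon gives an at least 1.0-fold higher number from compound 2 to compound 4 (0.02 log units; that floor lies within the scatter), a floor that lies within the scatter, so no effect of the fluorine can be claimed. The change from 4-methoxyphenyl to phenyl cannot be read, because compound 3 and compound 4 both stand only as limits: the limit of > 60000 nM in this assay, at which 2 of the 4 values shown sit.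

The compounds shown leave open whether an amine or a hydroxyl in place of the methoxy would bring a readable number. They also leave open how an ethyl or a longer chain on the aromatic nitrogen would compare with methyl.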